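A few compounds are considered here, and "the series" means these few. Any claim that something is new, unique, unknown or untested is made for them only; others in the source may bear on it.

Compound 1 `Cc1ccc2cccc(NC(=O)c3cnccn3)c2n1`: in a functional assay on MIA PaCa-2 cells (Homo sapiens) for inhibition, read by MTT assay, with a stated time of 72 h (a lower number here means a stronger inhibitor, a higher number a weaker inhibitor), compound 1 gives > 10000 nM, a limit of the assay rather than a number.
Compound 2 `O=C(Nc1cc(F)cc2cccnc12)c1cnccn1`: in this assay compound 2 gives 130 nM.
Compound 3 `Cc1ccc2cccc(NC(=O)c3ncccn3)c2n1`: in this assay compound 3 gives > 10000 nM, again a limit of the assay.

Compound 2 is thus the only one of the three with a number; the other two sit at the limit of > 10000 nM in this assay, at which 2 of the 3 values shown sit. Compound 3 differs from compound 1 by pyrimidin-2-yl in place of pyrazin-2-yl on a carbonyl carbon, and that step, a step that the two limits leave unreadable from compound 1 to compound 3, cannot be read, since both ends are limits. The difference between the cores of compound 1 and compound 2 is not broken down here. Compound 4 `O=C(Nc1cc(F)cc2cccnc12)c1ncccn1`, not yet measured, differs from compound 2 by pyrimidin-2-yl in place of pyrazin-2-yl on a carbonyl carbon, the same change as from compound 1 to compound 3. Nothing measured shows how large that change is, so the expectation for compound 4 rests mainly on compound 2 and its value 130 nM, with wide room either way. Compound 4 is expected to lie near 300 nM in this assay, between 60 nM and 3000 nM. That estimate means a step of a 2.3-fold higher number from compound 2 to compound 4 (0.36 log units; beyond the scatter), a modest expected loss.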

Compound 4, half-maximal inhibitory concentration: 300 nM
Compound 4: middle estimate and measured number agree at the digits printed; low and high end bracket the measured number.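

In this assay, pyrimidin-2-yl in place of pyrazin-2-yl on the carbonyl carbon brings a 2.3-fold higher number from compound 2 to compound 4 (0.36 log units; beyond the scatter), so on the core of compound 2 the change weakens inhibition modestly and leaves a clear number. The same change also links compound 1 to compound 3, but that step cannot be read, since both ends are limits of the assay and not numbers: the limit of > 10000 nM in this assay, at which 2 of the 4 values shown sit. The size of the change is therefore known on one core only, and the compounds shown neither prove nor rule out that it would be similar on the core of compound 1.

Open, on these data alone, is how other groups on the carbonyl carbon, such as phenyl or pyridin-2-yl, would compare with pyrazin-2-yl and pyrimidin-2-yl on the core of compound 2. Also open, as far as these compounds go, is whether an amine or a carboxylic acid attached to either of these rings would strengthen or weaken inhibition in this assay.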